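The source may hold more compounds than are shown below. What is called first, only, known or untested is meant among the compounds shown, and "the series" means these compounds.

Measured so far:

Compound 1, `COc1cc(NC(=O)Nc2cc(Nc3ccc(C)c(C)c3)ncn2)cc(OC)c1`, in a functional assay on NCI-H226 cells (Homo sapiens) for inhibition, read by MTT assay, with a stated time of 48 h, tested at 10 uM (on this read-out lower numbers stand for less inhibition and higher numbers for more inhibition at the one concentration tested (going by the name of the read-out)), gives 45.3%.
Compound 2, `COc1cc(NC(=O)Nc2cc(Nc3ccc(C)c(F)c3)ncn2)cc(OC)c1`, in this assay gives 39.7%.
Compound 3, `COc1cc(NC(=O)Nc2cc(Nc3cc(Br)ccc3OC)ncn2)cc(OC)c1`, in this assay gives 42.7%.

Compound 3 stands second highest of these three numbers, but the gaps on either side are small: a number 2.6 percentage points lower from compound 1 to compound 3 (within the scatter), and a number 3 percentage points higher from compound 2 to compound 3 (within the scatter). So the three compounds are not separated by more than the ordinary scatter of the method, and none can be said to give a higher or lower number than the others.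

Compound 4, `COc1cc(NC(=O)Nc2cc(Nc3ccc(OC)c(I)c3)ncn2)cc(OC)c1`, has not yet been tested. It differs from compound 3 in one place: 3-iodo-4-methoxyphenyl in place of 5-bromo-2-methoxyphenyl on a nitrogen on an aromatic ring.

Among the measured compounds shown here, three measured steps bear on this. Two of them exchange the whole group on this nitrogen, a number 2.6 percentage points lower from compound 1 to compound 3 (within the scatter) and a number 3 percentage points higher from compound 2 to compound 3 (within the scatter), and one alters a single substituent inside that group, a number 5.6 percentage points lower from compound 1 to compound 2 (within the scatter). Every one of these stayed within the scatter. Exchanging one halogen-and-methoxy-bearing phenyl for another on the same nitrogen is therefore expected to leave this assay unchanged beyond the scatter: a number 0.7 percentage points lower from compound 3 to compound 4 (within the scatter).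

For compound 4 the expected result in this assay is 42%, estimated to lie between 30% and 54%.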

Compound 4, a percentage reported as inhibition, at one concentration (the size of the read-out at that concentration, not a potency): 40.1%
Estimate against measurement, compound 4: 1.9 percentage points above, and the stated range covers the measured number.
By their numbers in this assay, from the lowest: compounds 2, 4, 3 and 1 (each within the scatter of the next).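

The exchange of 5-bromo-2-methoxyphenyl for 3-iodo-4-methoxyphenyl on this nitrogen changes the halogen and the places of both substituents at once, and in this assay it gives a number 2.6 percentage points lower from compound 3 to compound 4 (within the scatter) as its result. The new group also stays close to the other two groups tried here, with a number 0.4 percentage points higher from compound 2 to compound 4 (within the scatter) on one side and a number 5.2 percentage points lower from compound 1 to compound 4 (within the scatter) on the other, so all four substituted phenyl groups now lie within the scatter of one another and this assay does not separate them. No measurement is available that would explain this lack of separation.

What the compounds shown leave open is whether an amine or a carboxylic acid on this phenyl ring, or a cyclohexyl ring in its place, would move the number beyond the scatter. The rest of the shared core is the same in all four compounds, so they also cannot tell how much its other parts contribute to the inhibition read here.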